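The compounds below may be only part of what the source reports. "The series", "measured", "known", "first", "only" and "open" are said of these compounds alone.

Measured in a functional assay on the whole organism with Mus musculus as the target; on this read-out lower numbers stand for an effect already at smaller amounts and higher numbers for an effect only at larger amounts of compound:
- Compound 1 `Cc1c(N)c(C)c2c(c1CN(C)C)OC(C)(C)C2`: > 50 mg/kg, which is a limit and not a number
- Compound 2 `Cc1c(C)c2c(c(C)c1N)CC(C)(CSc1ccncc1)O2`: 19.9 mg/kg
- Compound 3 `Cc1c(C)c2c(c(C)c1N)CC(C)(CSCc1ccccc1)O2`: 32 mg/kg

Compound 2 has one true number to compare with, and the two cannot be told apart: the step is a 1.6-fold higher number from compound 2 to compound 3 (0.21 log units; within the scatter).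

Compound 4 `Cc1c(C)c2c(c(C)c1N)CC(C)(CN1CCN(C)CC1)O2` is not yet measured. It carries 4-methylpiperazin-1-yl in place of (pyridin-4-yl)sulfanyl on a saturated chain carbon bound to a saturated ring carbon.

Among the compounds with values here, the one measured step, a 1.6-fold higher number from compound 2 to compound 3 (0.21 log units; within the scatter), only changed the group on a sulfur, and compound 4 has no sulfur there, so it is a weak guide. the limit of > 50 mg/kg in this assay, at which 1 of the 3 values shown sits, is a reminder that a compound can end at the limit. The expected change is therefore small, a 1.3-fold higher number from compound 2 to compound 4 (0.10 log units; within the scatter), inside the usual scatter. For compound 4 the estimated value is 25 mg/kg, with an expected range of 10 mg/kg to 60 mg/kg.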

Compound 4, dose for 50% inhibition: 25.3 mg/kg
Beside the measured number, compound 4's estimate is 1.0-fold (0.01 log units) below it, and the stated range covers the measured number.
By their numbers in this assay, from the lowest: compounds 2, 4 and 3 (each within the scatter of the next). At a limit, above all of these: compound 1.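

Within the data shown here, the step to the piperazine is the first at this place to remove the sulfur and the aromatic ring, not just to alter the group on the sulfur, and it gives a 1.3-fold higher number from compound 2 to compound 4 (0.10 log units; within the scatter). In this assay, a sulfur-linked pyridine and a non-aromatic 4-methylpiperazin-1-yl on this saturated chain carbon therefore cannot be told apart. Nothing measured here offers an explanation for this.

As far as these compounds go, what a carboxylic acid or an open-chain amine would do in this place stays open. So does whether any group here can bring the number clearly lower.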